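This account rests on a few compounds, and the source may have more. Where it says the series, first, only, none or still open, it means among the compounds named here.

Measured so far:
compound 1 `Nc1cc(N)c2nc(-c3ccccc3)c(Oc3ccc(Cl)c(Cl)c3)nc2c1` gives < 100000 nM in a functional assay on HCT-116 cells (Homo sapiens) for inhibition, read by sulforhodamine B assay, with a stated time of 48 h; a lower number here means that less compound is tolerated, a higher number that more compound is tolerated
compound 2 `CCOC(=O)[C@H](CCC(=O)O)NC(=O)c1ccc(CNc2nc3cc(N)cc(N)c3nc2-c2ccccc2)cc1` gives < 100000 nM
compound 3 `CCOC(=O)[C@H](CCC(=O)O)NC(=O)c1ccc(Sc2nc3cc(N)cc(N)c3nc2-c2ccccc2)cc1` gives < 100000 nM

All three numbers are limits of the assay rather than measured values. For compound 1 the figure < 100000 nM is such a limit. The same holds for compound 2, whose figure < 100000 nM is a limit. Compound 3 likewise sits at a limit with < 100000 nM. Compound 1 therefore cannot be placed in order against compound 2 or compound 3 on these numbers; all that is shown is the limit of < 100000 nM in this assay, at which 3 of the 3 values shown sit.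

Compound 4 `Nc1cc(N)c2nc(-c3ccccc3)c(Oc3ccc(F)cc3)nc2c1` is not yet measured. It differs from compound 1 in one place: 4-fluorophenyl in place of 3,4-dichlorophenyl on an oxygen on an aromatic ring. No measured step between compounds is available to set the size of this change, so the expectation rests only on the limit shown for compound 1. Compound 4 is expected to give about 40000 nM in this assay, with a range from 8000 nM to 100000 nM. That estimate means a step from compound 1 to compound 4 of a step that the limit leaves unreadable from compound 1 to compound 4, which is no change beyond the scatter, and the result may again come back only as a limit.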

Compound 4, concentration lethal to 50% of the cells: < 100000 nM
Compound 4: a limit, no number; the forecaster's own chance of this, stated with the estimate: 60%; the middle value is on the limit's open side.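

Going by these compounds alone, compound 1 and compound 4 both come back only as limits, so no step between them can be read: the limit of < 100000 nM in this assay, at which 4 of the 4 values shown sit.
As far as these compounds go, how far each compound's true lethal concentration lies from that limit, and whether 4-fluorophenyl in place of 3,4-dichlorophenyl changes it at all, remains open.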